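Notes on compounds 1 to 4 in a growth assay

The compounds below may be only part of what the source reports. "The series", "measured", "known", "first", "only" and "open" are said of these compounds alone.

Measured so far:
- compound 1, `COc1ccccc1/C=C/C(=O)/C=C/c1ccc(OCc2cn(CCOc3cc(=O)oc4ccccc34)nn2)c(OC)c1`: 11%
- compound 2, `COc1cc(/C=C/C(=O)/C=C/c2cc(OC)c(OC)c(OC)c2)ccc1OCc1cn(CCCCCOc2cc(=O)oc3ccccc23)nn1`: "not active" (no number reported)
- compound 3, `COc1cccc(/C=C/C(=O)/C=C/c2ccc(OCc3cn(CCCCOc4cc(=O)oc5ccccc45)nn3)c(OC)c2)c1`: "not active" (no number reported)

In a functional assay on PC-3 cells (Homo sapiens) for inhibition, read by sulforhodamine B assay, with a stated time of 48 h, tested at 50 uM (a lower number here means less inhibition of growth, a higher number more inhibition of growth at the concentration tested), compound 1 gives 11%. Compound 2 gives "not active" (no number reported), with no single number reported, and compound 3 is likewise reported without a number as "not active" (no number reported). Compound 2 therefore stands among the entries without a number, together with one further compound; only compound 1 carries a value, and that value is small. Within the data shown here, no step between measured compounds is available in this assay.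

Compound 4, `COc1ccc(/C=C/C(=O)/C=C/c2ccc(OCc3cn(CCCCCOc4cc(=O)oc5ccccc45)nn3)c(OC)c2)cc1OC`, is not yet measured. It differs from compound 2 by hydrogen in place of methoxy on an aromatic carbon. Among the measured compounds shown here, nothing among the measured compounds speaks for a step beyond the scatter: compound 1 shows 11% and the two others lack numbers. For the measured compounds named here, the expectation for compound 4 in this assay is low inhibition, close to what compounds 2 and 3 show, with no step from compound 2 beyond the scatter. Compound 4 is estimated at 10%, range 0% to 25%.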

Compound 4, percent growth inhibition at one concentration: "not active" (no number reported)
For compound 4 the study gives words and no number, so the estimate cannot be set against anything.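

In this assay compound 2 gives "not active" (no number reported) and compound 4 gives "not active" (no number reported) so no step can be read for 3,4,5-trimethoxyphenyl to 3,4-dimethoxyphenyl. The compounds shown leave open whether this change alters growth inhibition at all, and no evidence bears on the result.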